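The compounds below may be only part of what the source reports. "The series", "measured", "known", "first", "only" and "open" are said of these compounds alone.

Compound 2 `COc1cc(N/C(CCNC2=CC(=O)c3ccccc3C2=O)=N\S(=O)(=O)c2ccc(C)cc2)cc(OC)c1OC` gives 3050 nM in a functional assay on MCF7 cells (Homo sapiens) for cytotoxicity, read by MTT assay, with a stated time of 48 h (a lower number here means a stronger inhibitor, a higher number a weaker inhibitor), and compound 1 `Cc1ccc(S(=O)(=O)/N=C(/CCNC2=CC(=O)c3ccccc3C2=O)Nc2ccccc2[N+](=O)[O-])cc1` gives 3090 nM, the two numbers lying within the scatter of each other. Among the compounds with values here, the single measured step, a 1.0-fold lower number from compound 1 to compound 2 (0.01 log units; within the scatter), exchanged one aryl group for another on the amine nitrogen. Compound 3 `Cc1ccc(S(=O)(=O)/N=C(\N)CCNC2=CC(=O)c3ccccc3C2=O)cc1` differs from compound 2 by hydrogen in place of 3,4,5-trimethoxyphenyl on an amine nitrogen. Within the data shown here, no measured step covers removing an aryl group from this nitrogen entirely; the only guide is that swapping aryl groups left this assay unchanged. Compound 3 is therefore expected to shift by a 1.5-fold higher number from compound 2 to compound 3 (0.17 log units; within the scatter), with a wide range. The estimate for compound 3 is 4500 nM, expected to fall between 1500 nM and 14000 nM.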

Compound 3, half-maximal inhibitory concentration: 18600 nM
Compound 3: middle estimate off by 4.1-fold (0.62 log units), on the low side; measured number outside the range, above it.
By their numbers in this assay, from the lowest: compounds 2 and 1 (each within the scatter of the next); then compound 3.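

Across this assay, an aryl group on this amine nitrogen proved to matter, although exchanging one aryl group for another had not: removing either one gave a higher number (a 6.1-fold higher number from compound 2 to compound 3 (0.79 log units; beyond the scatter)) (a 6.0-fold higher number from compound 1 to compound 3 (0.78 log units; beyond the scatter)). Thus compound 1 and compound 2, despite carrying different aryl groups, both stand apart from compound 3 with hydrogen at this position. Nothing measured here accounts for this difference. As far as these compounds go, whether a methyl group, an unsubstituted phenyl or a benzyl group on this nitrogen would give numbers like those of compound 1 and compound 2 remains open.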